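The source may hold more compounds than are shown below. What is called first, only, known or untested is meant among the compounds shown, and "the series" means these compounds.

Measured in an ADME assay on HEK293 cells (Homo sapiens) for cytotoxicity, read by resazurin assay, with a stated time of 48 h; on this read-out higher numbers stand for lower toxicity in this test and lower numbers for higher toxicity in this test:

- Compound 1 `COc1ccc(S(=O)(=O)Nc2ccc3oc(-c4ccc(NC(=O)c5cccc(C)c5[N+](=O)[O-])cc4)nc3c2)cc1`: 12000 nM
- Compound 2 `COc1ccc(S(=O)(=O)Nc2ccc3oc(-c4ccc(NC(=O)c5ccc(Cl)s5)cc4)nc3c2)cc1`: 15000 nM
- Compound 3 `O=S(=O)(Nc1ccc(-c2nc3cc(NS(=O)(=O)c4cccc5ccccc45)ccc3o2)cc1)c1cccc2ccccc12`: > 100000 nM (a limit of the assay, not a number)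

Compound 2 stands level with compound 1, since a 1.3-fold higher number from compound 1 to compound 2 (0.10 log units; within the scatter). For compound 3 there is no number, only (the limit of > 100000 nM in this assay, at which 1 of the 3 values shown sits).

The step to follow leads to compound 4 `COc1ccc(S(=O)(=O)Nc2ccc3oc(-c4ccc(NS(=O)(=O)c5cc(F)ccc5OC)cc4)nc3c2)cc1`. The change is a group of 12 heavy atoms (7 carbon, 3 oxygen, 1 fluorine, 1 sulfur; one six-membered aromatic ring of carbon only) in place of a group of 8 heavy atoms (5 carbon, 1 oxygen, 1 sulfur, 1 chlorine; one five-membered aromatic ring with 1 hetero atom), on a nitrogen on an aromatic ring. It replaces one aromatic group with another and also removes the carbonyl.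

Among the measured compounds shown here, only one measured step bears on this change. The swap of aromatic groups in a 1.3-fold higher number from compound 1 to compound 2 (0.10 log units; within the scatter) left the number within the scatter, although that swap took place on a carbonyl carbon and kept the carbonyl. It is therefore weak guidance here.

The expected size of the change is a 1.5-fold higher number from compound 2 to compound 4 (0.17 log units; within the scatter), so no step beyond the scatter is expected. The wide upper end of the range rests on compound 3 and its limit of > 100000 nM.

For compound 4 the estimated value is 22000 nM, with an expected range of 7000 nM to 70000 nM.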

Compound 4, half-maximal cytotoxic concentration: 24000 nM
For compound 4 the middle estimate is 1.1-fold (0.04 log units) below the measured one; the range from low to high includes it.
By their numbers in this assay, from the lowest: compounds 1, 2 and 4 (each within the scatter of the next). At a limit, above all of these: compound 3.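

In this assay the group on this nitrogen can change in more than its aromatic part without the number leaving the scatter (a 1.6-fold higher number from compound 2 to compound 4 (0.20 log units; within the scatter)) and (a 2.0-fold higher number from compound 1 to compound 4 (0.30 log units; within the scatter)). The earlier step swapped aromatic groups but kept the carbonyl, whereas here the carbonyl is gone and a group of 12 heavy atoms with a six-membered aromatic ring of carbon only enters. Nothing measured here gives a cause for this lack of change.

Still open, on these data alone, is whether any group on this nitrogen can move the number beyond the scatter, for instance a simple alkyl chain, an amine or a carboxylic acid in place of the aromatic ring. Compound 3 gives > 100000 nM as a limit of the assay and not a number, and it differs from the others in more than one place, so it cannot settle this.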